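From an allyl chain to a 2-methoxyethyl chain

A few compounds are considered here, and "the series" means these few. Any claim that something is new, unique, unknown or untested is made for them only; others in the source may bear on it.

- compound 1 `Cn1ncc(Cl)c1-c1cc(C(=O)N[C@@H]2CN[C@H](CC(O)CO)C[C@H]2c2ccc(F)c(F)c2)oc1Cl`: 690 nM
- compound 2 `CC(=O)NCC[C@@H]1C[C@@H](c2ccc(F)c(F)c2)[C@H](NC(=O)c2cc(-c3c(Cl)cnn3C)c(Cl)o2)CN1`: 880 nM
- compound 3 `C=CC[C@@H]1C[C@@H](c2ccc(Cl)c(Cl)c2)[C@H](NC(=O)c2cc(-c3c(Cl)cnn3C)c(Cl)o2)CN1`: 990 nM

In a functional assay on OVCAR-8 cells (Homo sapiens) for antiproliferative activity (on this read-out lower numbers stand for stronger inhibition and higher numbers for weaker inhibition), compound 3 gives 990 nM, which lies within the scatter of the values for both compound 1 and compound 2. The three compounds therefore cannot be told apart on these numbers.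

The next compound, compound 4 `COCC[C@@H]1C[C@@H](c2ccc(Cl)c(Cl)c2)[C@H](NC(=O)c2cc(-c3c(Cl)cnn3C)c(Cl)o2)CN1`, differs from compound 3 at one place: methoxymethyl in place of vinyl on a saturated chain carbon bound to a saturated ring carbon. In words, methoxymethyl stands in place of vinyl on a saturated chain carbon bound to a saturated ring carbon, which amounts to allyl becoming 2-methoxyethyl.

Among the compounds with values here, no measured step makes this exact swap. The closest evidence is a change at the same kind of place, acetamidomethyl in place of 1,2-dihydroxyethyl, and that step was a 1.3-fold higher number from compound 1 to compound 2 (0.11 log units; within the scatter). Within the data shown here, it is only one step, but it gives no reason to expect a large change here. The expected result is a 1.1-fold lower number from compound 3 to compound 4 (0.04 log units; within the scatter), which would be no real change beyond the scatter. For compound 4 the estimated value is 900 nM, with an expected range of 400 nM to 1900 nM.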

Compound 4, half-maximal inhibitory concentration: 1060 nM
Beside the measured number, compound 4's estimate is 1.2-fold (0.07 log units) below it, and the stated range covers the measured number.
By their numbers in this assay, from the lowest: compounds 1, 2, 3 and 4 (each within the scatter of the next).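

Replacing vinyl with methoxymethyl gives a 1.1-fold higher number from compound 3 to compound 4 (0.03 log units; within the scatter) in this assay, so adding a hydrogen-bond acceptor and removing the double bond outside aromatic rings produces no change beyond the scatter here. The earlier step at this kind of place exchanged one chain carrying oxygen or nitrogen for another, whereas this step starts from allyl, a chain of carbon and hydrogen only, and ends at 2-methoxyethyl. At this place, then, a chain with no oxygen and a chain with an ether oxygen cannot be told apart on these numbers, and no further measurement bears on this result.

From the compounds shown here alone, it remains open whether a chain ending in an amine or a carboxylic acid would also stay within the scatter. The same question applies to a longer chain at this place.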